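The source may report more compounds than this note shows. Statements on the series, on what has been measured and on what is new or still open speak of the compounds shown alone.

Working notes on the series

The shared core carries a pyridazinone amide linked to an aryl ether. Compound 1 `Cc1cc(=O)n(-c2ccc(Br)cc2F)nc1C(=O)Nc1ccc(Oc2ncnc3[nH]ccc23)cc1` gives 3210 nM in a functional assay on MCF7 cells (Homo sapiens) for cytotoxicity, read by MTT assay, with a stated time of 72 h; on this read-out higher numbers stand for weaker inhibition and lower numbers for stronger inhibition. Compound 2 `Cc1cc(=O)n(-c2ccc(Br)cc2F)nc1C(=O)Nc1ccc(Oc2ncnc3[nH]ccc23)c(F)c1` gives 26600 nM in this assay and stands highest of the three numbers measured, that is, weakest on this read-out. Compound 3 `Cc1cc(=O)n(-c2cccc(C(F)(F)F)c2)nc1C(=O)Nc1ccc(Oc2ncnc3[nH]ccc23)c(F)c1` gives 11800 nM in this assay. The two measured steps are an 8.3-fold higher number from compound 1 to compound 2 (0.92 log units; beyond the scatter) and a 2.3-fold lower number from compound 2 to compound 3 (0.35 log units; beyond the scatter); both sit on the amide-side ring or on the aryl group of the pyridazinone, and neither touches the fused bicyclic ether end of the molecule.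

Compound 4 `Cc1cc(=O)n(-c2ccc(Br)cc2F)nc1C(=O)Nc1ccc(Oc2ncnc3c2ccn3C)c(F)c1` differs from compound 2 by one change: methyl in place of hydrogen on an aromatic nitrogen. Going by the values given here, no measured step in this set bears on that position, so no direct precedent exists for its size or direction. The measured steps show that single-atom changes on this scaffold have moved the number by modest amounts, so a change of that order is the working assumption, with the direction left open. For compound 4 the expected step is a 1.7-fold higher number from compound 2 to compound 4 (0.23 log units; within the scatter) in this assay, and compound 4 is estimated at 45000 nM, within a range from 12000 nM to 150000 nM.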

Compound 4, half-maximal inhibitory concentration: > 60000 nM
Compound 4 was reported as a limit; the forecaster's own chance of this, stated with the estimate: 30%; middle value at least 1.3-fold (0.12 log units) away from the limit.
By their numbers in this assay, from the lowest: compound 1; then compound 3; then compound 2. At a limit, above all of these: compound 4.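

Going by these compounds alone, the first change at the fused bicyclic end of the molecule sets the direction there: methyl in place of hydrogen on an aromatic nitrogen gives an at least 2.2-fold higher number from compound 2 to compound 4 (0.35 log units; beyond the scatter) in this assay, a step beyond the scatter that weakens inhibition on this read-out. For compound 4 the reading of > 60000 nM is a limit of the assay and not a number, so the step has a lower bound and no measured size. On this single pair, the hydrogen on the nitrogen of the five-membered aromatic ring cannot be replaced by methyl without a loss, and the true size of that loss stays unresolved: the limit of > 60000 nM in this assay, at which 1 of the 4 values shown sits.

The compounds shown leave open whether an ethyl group, or a longer chain ending in an amine, on that same nitrogen would follow methyl or read differently in this assay. Also open is whether the methyl step carries over to the core of compound 1, which lacks the added fluoro, or to compound 3, which bears 3-(trifluoromethyl)phenyl, since the change is shown on the core of compound 2 alone.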